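The compounds below may be only part of what the source reports. "The series", "measured", "known", "first", "only" and "open" are said of these compounds alone.

Measured so far:
compound 1, `N#CC1=C(NCN2CCCCC2)N(c2ccccc2)C(=O)N2CCCCC(N3CCCC3)C12`: 29.7%
compound 2, `N#Cc1c2n(c(=O)n(-c3ccccc3)c1=N)CCCCC2N1CCCC1`: 84.6%

In a functional assay on the whole organism (strain albino) for inhibition, with Rattus norvegicus as the target, read by paw edema, with a stated time of 1 h, at a dose of 20 mmol/kg by the intraperitoneal route (a higher number here means more inhibition at the dose given (going by the name of the read-out), a lower number less inhibition), compound 1 gives 29.7%, the lowest of the two numbers. Among the measured compounds shown here, compound 2 gives 84.6% in this assay, a value well beyond the scatter above compound 1; no step between the two is worked out, as they differ in more than one place.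

Compound 3, `COC(=O)C(=O)NC1=C(C#N)C2C(N3CCCC3)CCCCN2C(=O)N1c1ccccc1`, has not been measured. It differs from compound 1 by (methoxycarbonyl)carbonyl in place of (piperidin-1-yl)methyl on an amine nitrogen. For the measured compounds named here, no measured pair carries this kind of change, so there is no step to lean on. The expected step is a number 8.3 percentage points higher from compound 1 to compound 3 (within the scatter), small and upward, likely no larger than the scatter. Compound 3 is therefore estimated at 38% in this assay, with a range from 12% to 65%.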

Compound 3, a percentage reported as inhibition, in the whole organism at one dose (the size of the read-out at that dose, not a potency): 69.2%
Compound 3: the middle estimate sits 31.2 percentage points below what was measured, outside the stated range (above it).
By their numbers in this assay, from the lowest: compound 1; then compound 3; then compound 2.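

On the amine nitrogen, the substituent clearly matters in this assay: (methoxycarbonyl)carbonyl in place of (piperidin-1-yl)methyl gives a number 39.5 percentage points higher from compound 1 to compound 3 (beyond the scatter) and shows that this single change on the shared core is enough to move the read-out. The change removes a six-membered non-aromatic ring and brings in a group with no ring, 2 double bonds outside aromatic rings and 3 hydrogen-bond acceptors, and this one step cannot separate these differences. No available measurement accounts for the size of the step.

From the compounds shown here alone, it remains open whether the step depends on the methyl ester end of the new group or on the carbonyl attached to the amine nitrogen. A carboxylic acid, a plain acetyl group or a longer ester chain at this nitrogen would help separate these two parts.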